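The source may report more compounds than this note shows. Statements on the series, on what has been measured and on what is new or still open speak of the compounds shown alone.

Measured so far:
- compound 1, `Cc1nnc(SCc2cc(=O)c3ccccc3o2)o1`: > 25000 nM
- compound 2, `Cc1nnc(SCc2cc(=O)c3ccccc3o2)s1`: > 25000 nM
- compound 3, `Cc1nnc(SCc2coc3ccc(Cl)cc3c2=O)o1`: 3300 nM

Compound 1 carries the 5-methyl-1,3,4-oxadiazol-2-yl group on the sulfur. In a functional assay on MDA-MB-435S cells (Homo sapiens) for cytotoxicity, read by MTT assay, with a stated time of 72 h (on this read-out higher numbers stand for weaker inhibition and lower numbers for stronger inhibition), compound 1 gives only a limit, > 25000 nM, not a number. Compound 2 likewise sits at a limit in this assay, > 25000 nM. The step from compound 1 to compound 2 is therefore a step that the two limits leave unreadable from compound 1 to compound 2. Two of the three values in this assay are governed by the limit of > 25000 nM in this assay, at which 2 of the 3 values shown sit, so the series gives little to read from. Going by the values given here, compound 3, which carries a chloro on the fused ring, gives a number in this assay, 3300 nM; no step to compound 1 is computed, and only the two values stand side by side.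

Compound 4, `Cc1ccc2oc(CSc3nnc(C)o3)cc(=O)c2c1`, is not yet measured. It differs from compound 1 by methyl in place of hydrogen on an aromatic carbon. Among the compounds with values here, no measured step matches this change; the only step, from compound 1 to compound 2, is unreadable and concerns another site. Compound 3 shows that a substituent on the carbocyclic ring can yield a number in this assay. The estimate for compound 4 is accordingly 15000 nM, between 4000 nM and 50000 nM, which would mean an expected step of an at least 1.6-fold lower number from compound 1 to compound 4 (0.22 log units; that floor lies within the scatter); a further limit remains quite possible.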

Compound 4, half-maximal inhibitory concentration: > 25000 nM
Compound 4: no number, only a limit; the forecaster's own chance of this, stated with the estimate: 45%; middle value at least 1.6-fold (0.22 log units) from the limit.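

Compound 4 gives only a limit, > 25000 nM, and not a number; compound 1 also sits at a limit, so no step between compound 1 and compound 4 can be read: the limit of > 25000 nM in this assay, at which 3 of the 4 values shown sit.

The compounds shown leave open whether methyl in place of hydrogen on an aromatic carbon changes the result in this assay for the core of compound 1.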